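The compounds below may be only part of what the source reports. "The series", "measured", "known", "first", "only" and "open" are said of these compounds alone.

Compound 1, `O=S(=O)(O)c1ccc(/N=N/c2c(O)ccc3ccccc23)c2ccccc12`, sits at a limit in an assay on BaF3 cells with thrombopoietin receptor (Homo sapiens) as the target, read by a luciferase reporter (on this read-out higher numbers stand for larger maximal responses and lower numbers for smaller maximal responses), giving < 5%.
Compound 2, `Oc1ccc2ccccc2c1/N=N/c1c(O)ccc2ccccc12`, sits at a limit in this assay, giving < 5%.
Compound 3, `Cc1ccc(-n2[nH]c(C)c(/N=N/c3c(O)cc(S(=O)(=O)O)c4ccccc34)c2=O)cc1C`, gives 100% in this assay.

Among the compounds with values here, compound 3 holds the only number; the other two entries are limits (the limit of < 5% in this assay, at which 2 of the 3 values shown sit). Compound 4, `Cc1[nH]n(-c2ccc(O)cc2)c(=O)c1/N=N/c1c(O)cc(S(=O)(=O)O)c2ccccc12`, is not yet measured. It differs from compound 3 in one place: 4-hydroxyphenyl in place of 3,4-dimethylphenyl on an aromatic nitrogen. Within the data shown here, no measured step between two compounds is available, so the size of this step cannot be read from the data. With compound 3 at 100%, the change is expected to give a moderate loss in largest response, estimated as a number 20 percentage points lower from compound 3 to compound 4 (beyond the scatter). Compound 4 is estimated at 80%, with a range from 40% to 110%.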

Compound 4, largest response reached (reported as efficacy), in percent of the reference or control that the assay uses: < 5%
Compound 4: no number, only a limit; the forecaster's own chance of this, stated with the estimate: 15%; middle value at least 75 percentage points away from the limit.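

The group on this aromatic nitrogen proves decisive: 4-hydroxyphenyl in place of 3,4-dimethylphenyl gives, in this assay, a number at least 95 percentage points lower from compound 3 to compound 4 (beyond the scatter). One change at this position is enough to separate the response of compound 3 from the floor of the series. Compound 4 thus gives a limit, not a number: the limit of < 5% in this assay, at which 3 of the 4 values shown sit.

The compounds shown leave open whether the loss follows from gaining the hydroxyl group or from losing the two methyl groups. Also open, as far as these compounds go, is how plain phenyl, or a phenyl bearing an amine or a carboxylic acid, would read on this nitrogen.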